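The source may hold more compounds than are shown below. What is called first, only, known or untested is meant among the compounds shown, and "the series" means these compounds.

Measured compounds in a functional assay on cells (Homo sapiens) for cytotoxicity, read by MTT assay, with a stated time of 24 h; a lower number here means a stronger inhibitor, a higher number a weaker inhibitor:

compound 1, `CCCCCCCCCCCCCCNC(=O)[C@H](CO)/N=C/c1cccc(C)c1`: 82900 nM
compound 2, `CCCCCCCCCCCCCCNC(=O)[C@H](CO)/N=C/c1cccc([N+](=O)[O-])c1`: 104000 nM
compound 3, `CCCCCCCCCCCCCCNC(=O)[C@H](CO)/N=C/c1ccc([N+](=O)[O-])cc1`: 217000 nM

All three share the long chain amide and the hydroxymethyl-bearing stereocentre; they differ only in the aromatic ring attached to the carbon with a double bond to nitrogen. Compound 2 and compound 3 carry the same atoms joined differently, the difference being (4-nitrophenyl in place of 3-nitrophenyl on a carbon with a double bond to nitrogen); the step is a 2.1-fold higher number from compound 2 to compound 3 (0.32 log units; beyond the scatter). Compound 1 stands against compound 3 by a 2.6-fold higher number from compound 1 to compound 3 (0.42 log units; beyond the scatter).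

The change from compound 2 to compound 1 is methyl in place of nitro on an aromatic carbon, and it made a 1.3-fold lower number from compound 2 to compound 1 (0.10 log units; within the scatter), so on the ring of compound 2 this exchange is of no measurable consequence.

Compound 4, `CCCCCCCCCCCCCCNC(=O)[C@H](CO)/N=C/c1ccc(C)cc1`, is not yet measured. It arises from compound 3 by methyl in place of nitro on an aromatic carbon. This is the same kind of change as that from compound 2 to compound 1, not the same: there the methyl enters meta to a large group, here para to a large group. With only one earlier occurrence, and that one within the scatter, the expectation for compound 4 rests on compound 3 and on the step from compound 2 to compound 1 being a 1.3-fold lower number from compound 2 to compound 1 (0.10 log units; within the scatter). The step from compound 3 to compound 4 is expected to be a 1.3-fold lower number from compound 3 to compound 4 (0.11 log units; within the scatter), a number that need not differ from compound 3 beyond the scatter. Compound 4 is therefore estimated at 170000 nM, between 80000 nM and 360000 nM.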

Compound 4, half-maximal inhibitory concentration: 102000 nM
The estimate for compound 4 lay 1.7-fold (0.22 log units) above the measured number; measured number inside the range.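

In this assay, methyl in place of nitro on an aromatic carbon, para to a large group, gives a 2.1-fold lower number from compound 3 to compound 4 (0.33 log units; beyond the scatter), and this step does not differ measurably from the earlier occurrence of the same change on the other core: the same change on two cores in this assay, a 1.3-fold lower number (0.10 log units; within the scatter) from compound 2 to compound 1 and a 2.1-fold lower number (0.33 log units; beyond the scatter) from compound 3 to compound 4, 1.7-fold (0.23 log units) apart, within the scatter of two such steps

The two steps run in the same direction, and the measured steps of a 1.0-fold lower number from compound 2 to compound 4 (0.01 log units; within the scatter) and a 1.2-fold higher number from compound 1 to compound 4 (0.09 log units; within the scatter) leave the new methyl compound level with the two compounds on the other ring pattern, so among these four compounds only compound 3 stands apart. This does not establish a fixed size for the change that can be carried from core to core, since it rests on only two occurrences, one within the scatter and one beyond it, and the gap between them could hide a real but small dependence on where the group sits.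

What the compounds shown leave open is how a methoxy group, a chlorine, an amine or a carboxylic acid would read in place of nitro or methyl on this ring. Also open, from the compounds shown here alone, is whether the same change holds with a shorter chain in place of the long chain on the amide.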